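This account rests on a few compounds, and the source may have more. Where it says the series, first, only, none or still open, it means among the compounds named here.

Compound 1: `Cc1ccc(Cn2c(CN3CCN(C(=O)C4CC4)CC3)nc3ccccc32)cc1` gives 51.5%
Compound 2: `CCC(=O)N1CCN(Cc2nc3ccccc3n2Cc2cccc(C)c2)CC1` gives 85.1%

Both compounds share the same core and were tested in an assay on isolated protein for inhibition of aldehyde dehydrogenase 1A1 (Homo sapiens), read by spectrophotometry, tested at 10 uM; a lower number here means less inhibition, a higher number more inhibition at the concentration tested (going by the name of the read-out). Compound 1 gives 51.5%, the lower of the two readings. Compound 2 gives 85.1%, a reading that sits higher than that of compound 1 by more than the usual scatter of this kind of measurement. Compound 2 differs from compound 1 in more than one place, so these two values on their own say nothing about what any single change does.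

Compound 3, `O=C(C1CC1)N1CCN(Cc2nc3ccccc3n2CC2CC2)CC1`, has not yet been measured. It differs from compound 1 in one place: cyclopropyl in place of 4-methylphenyl on a saturated chain carbon bound to an aromatic nitrogen. Going by the values given here, no measured pair shows this change, so there is nothing to tell how large its effect is or which way it goes. Among the compounds with values here, with only the single reading of compound 1 as a starting point, the step is expected to be modest and downward, a number 11.5 percentage points lower from compound 1 to compound 3 (beyond the scatter), while a value within the scatter of compound 1 would not be surprising. Compound 3 is therefore estimated to give about 40% in this assay, with a likely range from 15% to 70%.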

Compound 3, a percentage reported as inhibition, at one concentration (the size of the read-out at that concentration, not a potency): 21.2%
Estimate against measurement, compound 3: 18.8 percentage points above; the measured number falls inside the stated range.
By their numbers in this assay, from the lowest: compound 3; then compound 1; then compound 2.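

In this assay putting cyclopropyl in place of 4-methylphenyl on a saturated chain carbon bound to an aromatic nitrogen brings a number 30.3 percentage points lower from compound 1 to compound 3 (beyond the scatter) and shows that what sits at this position matters for the reading. The change swaps one six-membered aromatic ring of carbon only for one three-membered non-aromatic ring of carbon only and takes the group from 7 heavy atoms to 3, while neither group has any hydrogen-bond donors, hydrogen-bond acceptors or net charge. Nothing available here explains why the reading drops.

This single step cannot separate the loss of the aromatic ring from the loss of size, and neither the 4-methyl group nor the ring itself can be singled out as the part that counts. A plain phenyl or a cyclohexyl at the same place would begin to pull these apart, and a longer chain such as n-butyl or a chain ending in an amine would show how much else this position accepts.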